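This account rests on a few compounds, and the source may have more. Where it says the series, first, only, none or still open, it means among the compounds named here.

Measured compounds:
Compound 1 `O=C(O)/C=C/c1ccc(/C(=C(\c2ccc(F)cc2Cl)C2CCC2)c2ccc3[nH]nc(F)c3c2)cc1` gives 2 nM in a functional assay on MCF7 cells (Homo sapiens) for cytotoxicity, read by CellTiter-Glo, with a stated time of 5 days; a lower number here means a stronger inhibitor, a higher number a weaker inhibitor.
Compound 2 `O=C(O)/C=C/c1ccc(/C(=C(\c2ccccn2)C2CCC2)c2ccc3[nH]nc(F)c3c2)cc1` gives 22 nM in this assay.

Compound 2 stands with the highest of the two numbers; its nearest neighbour is compound 1, and the step of an 11-fold higher number from compound 1 to compound 2 (1.04 log units; beyond the scatter) is a large one, beyond the scatter. Compound 3 `Cc1cccnc1/C(=C(\c1ccc(/C=C/C(=O)O)cc1)c1ccc2[nH]nc(F)c2c1)C1CCC1` has not yet been measured. It differs from compound 2 by methyl in place of hydrogen on an aromatic carbon, a change on the pyridin-2-yl group that sits on a double-bonded chain carbon of the shared core. For the measured compounds named here, no measured step covers adding a methyl group on this ring; the only step known swaps the whole aryl group, so it gives no direct guide here. With nothing pointing one way, the expectation for compound 3 is a step of a 1.5-fold lower number from compound 2 to compound 3 (0.17 log units; within the scatter) that stays within the scatter. Compound 3 is therefore estimated at 15 nM, with a range from 5 nM to 45 nM.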

Compound 3, half-maximal inhibitory concentration: 4.2 nM
Compound 3: middle estimate off by 3.6-fold (0.55 log units), on the high side, and the stated range ends above it.
By their numbers in this assay, from the lowest: compound 1; then compound 3; then compound 2.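

On the pyridin-2-yl ring, a single methyl group, ortho to a large group and two atoms from the ring nitrogen, is enough to give a 5.2-fold lower number from compound 2 to compound 3 (0.72 log units; beyond the scatter) in this assay. This closes much of the gap opened by the whole-group swap, which gave an 11-fold higher number from compound 1 to compound 2 (1.04 log units; beyond the scatter), although a difference beyond the scatter remains, with a 2.1-fold higher number from compound 1 to compound 3 (0.32 log units; beyond the scatter), so compound 1 keeps the lowest number of the three. Nothing measured here explains why this small addition has such an effect.

On these data alone, it remains open whether methyl is special at this place, or whether a chlorine atom, a methoxy group or an ethyl group on the same carbon would do as well. Also open, as far as these compounds go, is how a methyl group elsewhere on the ring would compare.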